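The source may hold more compounds than are shown below. What is called first, only, known or untested is meant among the compounds shown, and "the series" means these compounds.

Compound 2 `Cc1ccc(NC(=O)Cn2c(N)nc(CC3CCCC3)c2-c2ccccc2Br)cc1` carries a cyclopentyl on the saturated chain carbon bound to an aromatic carbon of the shared core. In a functional assay on MIA PaCa-2 cells (Homo sapiens) for antiproliferative activity, read by MTT assay, with a stated time of 48 h (on this read-out higher numbers stand for weaker inhibition and lower numbers for stronger inhibition), compound 2 gives 80500 nM, the highest of the two numbers in hand. Within the data shown here, the only comparison available is compound 1 `CCCCCCCc1nc(N)n(CC(=O)Nc2ccc(C)cc2)c1-c1ccccc1Br`, which differs solely in the hexyl at that carbon; in this assay compound 1 gives 7000 nM, and the step is a 12-fold higher number from compound 1 to compound 2 (1.06 log units; beyond the scatter). Compound 3 `COc1ccc(Cc2nc(N)n(CC(=O)Nc3ccc(C)cc3)c2-c2ccccc2Br)cc1` is the next variation at the same carbon: 4-methoxyphenyl in place of cyclopentyl on a saturated chain carbon bound to an aromatic carbon. Among the measured compounds shown here, no measured step covers an aromatic group at this carbon, so the direction is not settled; the single measured step shows only that this carbon is sensitive to what is attached. With compound 2 as the starting point, compound 3 is expected to give 30000 nM in this assay, within a range of 6000 nM to 150000 nM, a step of a 2.7-fold lower number from compound 2 to compound 3 (0.43 log units; beyond the scatter) that is an estimate rather than a trend.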

Compound 3, half-maximal inhibitory concentration: 5200 nM
Compound 3: the middle estimate sits 5.8-fold (0.76 log units) above what was measured; the measured number lies below the stated range.
By their numbers in this assay, from the lowest: compounds 3 and 1 (each within the scatter of the next); then compound 2.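

In this assay, 4-methoxyphenyl in place of cyclopentyl on the saturated chain carbon bound to an aromatic carbon gives a 15-fold lower number from compound 2 to compound 3 (1.19 log units; beyond the scatter) and so shows that an aromatic group at this carbon can reverse the loss seen with cyclopentyl. Against hexyl, the same group gives a 1.3-fold lower number from compound 1 to compound 3 (0.13 log units; within the scatter) and places two very different groups on a level, leaving cyclopentyl as the only one of the three that stands apart at this position. Nothing at hand bears on why these groups differ in this way.

Still open, going by these compounds, is whether a plain phenyl or a 4-hydroxyphenyl at this carbon would match the 4-methoxyphenyl, and whether a longer chain would match or pass the hexyl. The compounds shown also leave open how an amine or a carboxylic acid at the end of this group would read.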